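A few compounds are considered here, and "the series" means these few. Any claim that something is new, unique, unknown or untested is made for them only; others in the source may bear on it.

Measured compounds:
- Compound 1 `C=CC1=C(C(=O)NCc2ccccc2)C(c2ccc(Cl)c(Cl)c2)OC1` — in a functional assay on QGY7701 cells (Homo sapiens) for cytotoxicity, read by MTT assay, with a stated time of 24 h (on this read-out higher numbers stand for weaker inhibition and lower numbers for stronger inhibition), compound 1 gives > 100000 nM, which is a limit of the assay rather than a number.
- Compound 2 `C=CC1=C(C(=O)NCCC)C(c2ccc(OC)c(OC)c2)OC1` — in this assay compound 2 gives > 100000 nM, again a limit of the assay and not a number.

Both values sit at the limit of > 100000 nM in this assay, at which 2 of the 2 values shown sit, so neither compound has shown measurable cytotoxicity on these cells, and compound 2 stands at that same limit, with nothing that places it apart from compound 1.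

Compound 3 `C=CC1=C(C(=O)O)C(c2ccc(OC)c(OC)c2)OC1` differs from compound 2 in one place: hydroxy in place of propylamino on a carbonyl carbon. The propylamino group that formed the amide is gone, and a carboxylic acid stands in its place on the shared core of compound 2.

No measured step exists between any two of these compounds, so there is no precedent for how this change acts in this assay. Since compound 2 sits at the limit, only a change toward stronger inhibition could register as a number at all. The expected step from compound 2 to compound 3 is a step that the limit leaves unreadable from compound 2 to compound 3, which amounts to none beyond the scatter. Compound 3 is therefore expected to give about 150000 nM, within a range of 30000 nM to 500000 nM, and most likely the assay will again report only a limit.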

Compound 3, half-maximal inhibitory concentration: > 100000 nM
Compound 3 was reported as a limit (the forecaster's own chance of this, stated with the estimate: 85%); the middle value is on the limit's open side.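

In this assay compound 3 gives > 100000 nM as a limit of the assay and not a number. For the compounds shown here, compound 2 also stands at a limit, and no step from compound 2 to compound 3 can be read. The compounds shown leave open whether any change to the shared core would give a measurable value in this assay at all.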